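Estimating Cytotoxicity of a Dichlorophenyl Analogue

The compounds below may be only part of what the source reports. "The series", "measured", "known", "first", "only" and "open" are said of these compounds alone.

Compound 1 `Cc1ccc(N(C(=O)c2cccc(C)c2)C(=S)OCCN2C(=O)c3ccccc3C2=O)cc1` was tested in an ADME assay on MT4 cells (Homo sapiens) for cytotoxicity, read by MTT assay; on this read-out higher numbers stand for lower toxicity in this test and lower numbers for higher toxicity in this test. For compound 1 this test reports only a limit, > 100000 nM, rather than a number, so its cytotoxicity is not fixed to a value; it sits at the limit of > 100000 nM in this assay, at which 1 of the 3 values shown sits. Two related compounds were measured: compound 2 `O=C1c2ccccc2C(=O)N1CCOC(=S)N(C(=O)c1cc(F)ccc1F)c1ccc(Cl)cc1` gives 54000 nM and compound 3 `COc1cccc(OC)c1C(=O)N(C(=S)OCCN1C(=O)c2ccccc2C1=O)c1ccc(Cl)cc1` gives 69000 nM. The step of a 1.3-fold higher number from compound 2 to compound 3 (0.11 log units; within the scatter) shows that exchanging one aryl group on a carbonyl carbon left the readout essentially unchanged.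

Compound 4 `Cc1ccc(N(C(=O)c2ccc(Cl)c(Cl)c2)C(=S)OCCN2C(=O)c3ccccc3C2=O)cc1` differs from compound 1 by 3,4-dichlorophenyl in place of 3-methylphenyl on a carbonyl carbon. Within the data shown here, no measured step covers this exact exchange, and the single step between compounds 2 and 3 stayed within scatter, so no shift beyond scatter is expected. Compound 4 is therefore estimated at 80000 nM, between 30000 nM and 200000 nM, which is expected to mean an at least 1.2-fold lower number from compound 1 to compound 4 (0.09 log units; that floor lies within the scatter).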

Compound 4, half-maximal cytotoxic concentration: 17000 nM
Beside the measured number, compound 4's estimate is 4.7-fold (0.67 log units) above it; the measured number lies below the stated range.
By their numbers in this assay, from the lowest: compound 4; then compounds 2 and 3 (each within the scatter of the next). At a limit, above all of these: compound 1.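

Compounds 2 and 3 differ by an aryl exchange on a carbonyl carbon that stayed within the scatter, so they gave no sign that this position could move the read-out. Compounds 1 and 4 show that it can: 3,4-dichlorophenyl in place of 3-methylphenyl gives an at least 5.8-fold lower number from compound 1 to compound 4 (0.76 log units; beyond the scatter), which points to higher toxicity in this test.

On these data alone, whether a pyridine ring or a phenyl group carrying an amine or a carboxylic acid at this carbonyl carbon would shift the number remains open. The full size of the step also remains open, since the value of compound 1 is only a limit: the limit of > 100000 nM in this assay, at which 1 of the 4 values shown sits.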